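Amide-side change on the shared core: compound 3 to compound 4

The source may report more compounds than this note shows. Statements on the series, on what has been measured and on what is new or still open speak of the compounds shown alone.

Measured so far:
compound 1, `Cc1c(C(C)C)c(=O)on1C(=O)N1CCCCC1`, in an assay (strain Wistar) for inhibition of Hormone-sensitive lipase (Rattus norvegicus), read by spectrophotometry; a lower number here means a stronger inhibitor, a higher number a weaker inhibitor: 2 nM
compound 2, `Cc1c(C(C)C)c(=O)on1C(=O)N(C)Cc1ccco1`, in this assay: 4 nM
compound 3, `Cc1c(C(C)C)c(=O)on1C(=O)N(C)Cc1cccs1`, in this assay: 2 nM

Compound 3 stands level with compound 1 at the digits shown, the two together the lowest numbers; compound 2 sits within the scatter of both. Among the compounds with values here, the only step between neighbours is a 2.0-fold lower number from compound 2 to compound 3 (0.30 log units; within the scatter), one five-membered aromatic ring swapped for another.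

Compound 4, `Cc1c(C(C)C)c(=O)on1C(=O)N(C)CCC#N`, differs from compound 3 by cyanomethyl in place of thiophen-2-yl on a saturated chain carbon bound to an amide-type nitrogen. Within the data shown here, no measured step removes the ring at this position, so none bears directly; all three measured amide substituents sit within the scatter of one another, which points to tolerance, though every one of them carries a ring. A modest rise in number, a 3.0-fold higher number from compound 3 to compound 4 (0.48 log units; beyond the scatter), is expected for compound 4, with wide uncertainty. Compound 4 is estimated at 6 nM, range 1.5 nM to 25 nM.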

Compound 4, half-maximal inhibitory concentration: > 1000 nM
Compound 4 gave a limit, no number (the forecaster's own chance of this, stated with the estimate: 2%); middle value at least 160-fold (2.22 log units) away from the limit.
By their numbers in this assay, from the lowest: compounds 1, 3 and 2 (each within the scatter of the next). At a limit, above all of these: compound 4.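

In this assay compound 4 gives > 1000 nM, a limit of the assay and not a number. The tolerance seen among the ring-bearing amide substituents does not extend to 2-cyanoethyl, which has no ring: replacing thiophen-2-yl or furan-2-yl with cyanomethyl gives an at least 500-fold higher number from compound 3 to compound 4 (2.69 log units; beyond the scatter) and an at least 250-fold higher number from compound 2 to compound 4 (2.39 log units; beyond the scatter). The comparison with the piperidin-1-yl amide points the same way, with an at least 500-fold higher number from compound 1 to compound 4 (2.69 log units; beyond the scatter).

The compounds shown do not separate removal of the ring from entry of the nitrile. A plain propyl chain or a benzyl group in place of 2-cyanoethyl would address that question.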